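Trifluoromethyl in Place of Bromo: an Expected Antiproliferative Outcome

The source may hold more compounds than are shown below. What is called first, only, known or untested is meant among the compounds shown, and "the series" means these compounds.

Compound 1 `O=c1[nH]c(=O)n([C@H]2C[C@H](O)[C@@H](COP(=O)(O)O)O2)cc1Br` was tested in a functional assay on Raji cells (Homo sapiens) for antiproliferative activity; on this read-out lower numbers stand for stronger inhibition and higher numbers for weaker inhibition. In this assay compound 1 gives only a limit, > 1000 ug/mL, and not a number. Compound 2 `COP1(=O)OC[C@H]2O[C@@H](n3cc(Br)c(=O)[nH]c3=O)C[C@@H]2O1` is the other measured member of the set. In this assay compound 2 likewise gives only a limit, > 100 ug/mL. Going by the values given here, compound 1 therefore stands at a limit rather than at a measured value, as does the one other value shown: compound 1 sits at the limit of > 1000 ug/mL in this assay, at which 1 of the 2 values shown sits, and compound 2 at the limit of > 100 ug/mL in this assay, at which 1 of the 2 values shown sits. Among the compounds with values here, neither compound shows measurable inhibition, so no step between measured compounds can be stated. Compound 3 `O=c1[nH]c(=O)n([C@H]2C[C@H](O)[C@@H](COP(=O)(O)O)O2)cc1C(F)(F)F` is not yet measured in this assay. It differs from compound 1 by trifluoromethyl in place of bromo on an aromatic carbon. With both measured compounds at limits, there is no basis for expecting a gain, and the expected step of a number no higher from compound 1 to compound 3 (the limit leaves the size open) lies within the scatter. Compound 3 is accordingly estimated at about 1000 ug/mL, between 300 ug/mL and 3000 ug/mL, and is most likely to return only a limit once more.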

Compound 3, concentration for 50% inhibition: 212 ug/mL
Compound 3: the middle estimate sits 4.7-fold (0.67 log units) above what was measured; the whole stated range lies above it.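

In this assay, going by these compounds alone, compound 3 is the first member of the set to give a number rather than a limit, which shows that this position on an aromatic carbon of the six-membered aromatic ring with 2 nitrogen does respond to the group it carries. Trifluoromethyl in place of bromo gives an at least 4.7-fold lower number from compound 1 to compound 3 (0.67 log units; beyond the scatter), a step beyond the usual scatter, and neither the leaving nor the entering group carries a hydrogen-bond donor or acceptor. That step marks only the least the change achieves and not its full size, because compound 1 stands at a limit: the limit of > 1000 ug/mL in this assay, at which 1 of the 3 values shown sits.

A single pair cannot tell which feature of trifluoromethyl carries the step, and a methyl, a chloro or a nitrile on the same carbon would bear on that question. On these data alone, compound 2 gives only a limit, > 100 ug/mL, so whether the same change would act on the core of compound 2 stays open.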